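Carbonyl aryl exchange on the shared core: compound 3

This account rests on a few compounds, and the source may have more. Where it says the series, first, only, none or still open, it means among the compounds named here.

Compound 2 `COc1cc(C(=O)C2Sc3nnc(-c4cc(OC)c(OC)c(OC)c4)n3NC2c2ccco2)cc(OC)c1OC` gives only a limit in a functional assay on HepG2 cells (Homo sapiens) for cytotoxicity, read by MTT assay, with a stated time of 48 h (a higher number here means a weaker inhibitor, a lower number a stronger inhibitor), namely > 100000 nM. Compound 1 `COc1cc(-c2nnc3n2NC(c2ccco2)C(C(=O)c2ccccc2C)S3)cc(OC)c1OC` gives 63000 nM in this assay. Among the compounds with values here, the one measured step at the carbonyl is an at least 1.5-fold higher number from compound 1 to compound 2 (0.20 log units; that floor lies within the scatter), and compound 2 sits at the limit of > 100000 nM in this assay, at which 1 of the 2 values shown sits. Compound 3 `COc1cc(-c2nnc3n2NC(c2ccco2)C(C(=O)c2cccs2)S3)cc(OC)c1OC` differs from compound 2 by thiophen-2-yl in place of 3,4,5-trimethoxyphenyl on a carbonyl carbon. That measured step points in one direction only, away from 3,4,5-trimethoxyphenyl, so a move back toward the range of compound 1 seems plausible, though its size is uncertain and a further limit cannot be excluded. Compound 3 is therefore expected to give about 80000 nM, between 35000 nM and 150000 nM, which corresponds to an expected step of an at least 1.2-fold lower number from compound 2 to compound 3 (0.09 log units; that floor lies within the scatter).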

Compound 3, half-maximal inhibitory concentration: 64100 nM
Estimate against measurement, compound 3: 1.2-fold (0.10 log units) above; the measured number falls inside the stated range.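

Thiophen-2-yl on the carbonyl carbon now gives a second readable number at this position: in this assay the step is a 1.0-fold higher number from compound 1 to compound 3 (0.01 log units; within the scatter), so thiophen-2-yl and 2-methylphenyl cannot be told apart here. Against 3,4,5-trimethoxyphenyl there is only a floor, an at least 1.5-fold lower number from compound 2 to compound 3 (0.19 log units; that floor lies within the scatter), so the order of that pair stays unsettled. The value of compound 2 is a limit, not a number: the limit of > 100000 nM in this assay, at which 1 of the 3 values shown sits.

Open, on these data alone, is whether a phenyl ring carrying an amine or a carboxylic acid in this place would move the number. Also open, as far as these compounds go, is whether any carbonyl substituent separates from compound 1 beyond the scatter.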